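The compounds below may be only part of what the source reports. "The series", "measured", "known", "first", "only" and "open" are said of these compounds alone.

Working notes on the series, cytotoxicity in a functional assay on MCF7 cells (Homo sapiens) for cytotoxicity, read by sulforhodamine B assay, with a stated time of 48 h; a higher number here means a weaker inhibitor, a lower number a stronger inhibitor.

Compound 1 `CCc1ccccc1NS(=O)(=O)c1ccc(NC(=O)NCCCCl)cc1`: in this assay compound 1 reaches only the limit of the assay, > 200000 nM.
Compound 2 `CCCc1ccccc1NS(=O)(=O)c1ccc(NC(=O)NCCCCl)cc1`: in this assay compound 2 gives 35000 nM.
Compound 3 `CCNC(=O)Nc1ccc(S(=O)(=O)Oc2ccccc2CC)cc1`: in this assay compound 3 gives 3400 nM.

For the measured compounds named here, the one measured step within a single core is methyl in place of hydrogen on a saturated chain carbon, two bonds along the chain from an aromatic carbon, which reads as an at least 5.7-fold lower number from compound 1 to compound 2 (0.75 log units; beyond the scatter). Its true size is open at the top, because compound 1 sits at the limit of > 200000 nM in this assay, at which 1 of the 3 values shown sits, so only a lower bound of the step is known.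

Compound 3 is built on a different core; the difference between the core of compound 3 and the core of compound 1 is not broken down here. Of the two numbers in hand, compound 3 has the lower one and compound 2 the higher one, a gap beyond the scatter.

Compound 4 `CCCc1ccccc1OS(=O)(=O)c1ccc(NC(=O)NCC)cc1` has not yet been measured. It differs from compound 3 by methyl in place of hydrogen on a saturated chain carbon, two bonds along the chain from an aromatic carbon, the same change at the same place as that from compound 1 to compound 2, now made on the core of compound 3. As far as these compounds go, the expected step is a 2.3-fold lower number from compound 3 to compound 4 (0.36 log units; beyond the scatter), taken smaller than the earlier one, since that one starts from a limit and its full size is unknown, and the change is carried onto a core whose behaviour toward it is untested. Compound 4 is expected to give about 1500 nM in this assay, most likely between 500 nM and 5000 nM.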

Compound 4, half-maximal inhibitory concentration: 1300 nM
Beside the measured number, compound 4's estimate is 1.2-fold (0.06 log units) above it, within the range that was stated.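

In this assay, the change from ethyl to propyl, methyl in place of hydrogen on a saturated chain carbon, two bonds along the chain from an aromatic carbon, gives a 2.6-fold lower number from compound 3 to compound 4 (0.42 log units; beyond the scatter) on the second core. This shows that the change lowers the number on both cores, so its direction carries over in the two cases at hand, and the two steps can be set side by side: the same change on two cores in this assay, an at least 5.7-fold lower number (0.75 log units; beyond the scatter) from compound 1 to compound 2 and a 2.6-fold lower number (0.42 log units; beyond the scatter) from compound 3 to compound 4; the limit leaves it open whether they differ. Compound 1 gives > 200000 nM which is a limit of the assay and not a number, so these compounds do not show whether the size of the step carries over, and two cores alone give no rule for any further core.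

The compounds shown leave open how a longer chain than propyl, or a branched chain such as isopropyl, would read at the same place in this assay. Also open, as far as these compounds go, is whether the same lowering would hold with an amine or a carboxylic acid at the end of that chain, or with the change from ethyl to propyl carried onto a third core.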